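Removing tert-butoxycarbonyl from compound 3

The compounds below may be only part of what the source reports. "The series", "measured", "known", "first", "only" and "open" are said of these compounds alone.

In a functional assay on MCF7 cells (Homo sapiens) for inhibition, read by MTT assay, with a stated time of 72 h (on this read-out lower numbers stand for stronger inhibition and higher numbers for weaker inhibition), compound 3 (`CC(C)(C)OC[C@@H](NC(=O)c1cc(Cl)ccc1OCCNC(=O)OC(C)(C)C)C(=O)Nc1ccc([N+](=O)[O-])cc1Cl`) gives > 10000 nM, which is a limit and not a number. Across the series so far the picture is the limit of > 10000 nM in this assay, at which 3 of the 3 values shown sit, so no compound has yet given a readable value.

Compound 4 (`CC(C)(C)OC[C@@H](NC(=O)c1cc(Cl)ccc1OCCN)C(=O)Nc1ccc([N+](=O)[O-])cc1Cl`) is the next to be read. The change is hydrogen in place of tert-butoxycarbonyl on an amine nitrogen, or (tert-butoxycarbonyl)amino to amino. Among the measured compounds shown here, no measured step covers this change. For the measured compounds named here, the one measured step, a step that the two limits leave unreadable from compound 1 to compound 2, is a different substitution and offers no size to carry over.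

Going by the values given here, the only guide is therefore two compounds that already carry the 2-aminoethyl group of compound 4. Compound 1 (`CC(C)C[C@H](NC(=O)c1cc(Cl)ccc1OCCN)C(=O)Nc1ccc([N+](=O)[O-])cc1Cl`) has this group and stays at > 10000 nM, a limit. Compound 2 (`CSCC[C@H](NC(=O)c1cc(Cl)ccc1OCCN)C(=O)Nc1ccc([N+](=O)[O-])cc1Cl`) also has it and stays at > 10000 nM, again a limit.

Loss of the tert-butoxycarbonyl group is thus not expected to give a clear gain in this assay, and no readable shift in either direction is anticipated. The estimated step is a number no higher from compound 3 to compound 4 (the limit leaves the size open). For compound 4 the expected value is 10000 nM, with an estimated range of 3000 nM to 30000 nM, and a report at the limit is the likeliest outcome.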

Compound 4, half-maximal inhibitory concentration: 1620 nM
Compound 4: middle estimate off by 6.2-fold (0.79 log units), on the high side; measured number below the stated range.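

In this assay, taking the tert-butoxycarbonyl group off the amine nitrogen gives an at least 6.1-fold lower number from compound 3 to compound 4 (0.79 log units; beyond the scatter), so the group on this nitrogen can decide whether a readable value appears at all. The 2-aminoethyl group is not enough on its own, since compound 1 and compound 2 carry it and still sit at the limit of the assay; in the compounds shown, a readable value comes only from its combination with the side chain of compound 4. That makes compound 4 the single reference point in the series so far, and every other compound can be compared with it only as a limit: the limit of > 10000 nM in this assay, at which 3 of the 4 values shown sit.

The compounds shown leave open whether the free primary amine itself is needed or whether other small groups on this nitrogen, such as an acetyl amide or a dimethylamine, would also give a readable value. They also leave open how the value responds to a longer chain such as 3-aminopropyl, and whether the tert-butyl ether in the side chain of compound 4 can give way to a free hydroxyl.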